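The source may report more compounds than this note shows. Statements on the series, on what has been measured and on what is new or still open speak of the compounds shown alone.

Measured so far:
- compound 1 `CN(C)CCN1CCN(c2nc(-c3ccccn3)nc3c2CN(C(=O)c2ccccc2)CC3)CC1`: 100000 nM
- compound 2 `Fc1ccc(CN2CCc3nc(-c4ccccn4)nc(NCCCN4CCCC4)c3C2)cc1`: 200 nM

In an assay on cells with Cystic fibrosis transmembrane conductance regulator variant F508del (Homo sapiens) as the target, read by fluorescence, with stated times of 24 h and 30 min (a higher number here means that more compound is needed for the effect, a lower number that less compound is needed), compound 2 gives 200 nM, the lower of the two numbers; compound 1 gives 100000 nM, a gap well beyond the scatter. Compound 3 `CN(C)CCN1CCN(c2nc(-c3ccccn3)nc3c2CN(Cc2ccc(F)cc2)CC3)CC1` keeps the 4-fluorobenzyl of compound 2 and carries the change (4-(2-(dimethylamino)ethyl)piperazin-1-yl in place of (3-(pyrrolidin-1-yl)propyl)amino on an aromatic carbon). Going by these compounds, the same 4-(2-(dimethylamino)ethyl)piperazin-1-yl group sits on compound 1, though compound 1 also differs elsewhere, so the contribution of this group alone is unknown. An increase is expected, a 13-fold higher number from compound 2 to compound 3 (1.10 log units; beyond the scatter), of uncertain size. For compound 3 the estimate is 2500 nM, range 250 nM to 40000 nM.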

Compound 3, half-maximal effective concentration: 100000 nM
Beside the measured number, compound 3's estimate is 40-fold (1.60 log units) below it, and the stated range ends below it.
By their numbers in this assay, from the lowest: compound 2; then compounds 1 and 3 (each within the scatter of the next).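

In this assay, the group on this aromatic carbon carries a large effect: 4-(2-(dimethylamino)ethyl)piperazin-1-yl in place of (3-(pyrrolidin-1-yl)propyl)amino gives a 500-fold higher number from compound 2 to compound 3 (2.70 log units; beyond the scatter). With that piperazine group held, 4-fluorobenzyl in place of benzoyl on the ring amine nitrogen gives no change at the digits printed from compound 1 to compound 3 (within the scatter). No supporting data explain either step.

Still open, going by these compounds, is whether (3-(pyrrolidin-1-yl)propyl)amino would hold its value with benzoyl on the ring nitrogen. Also open, on these data alone, is what a morpholine or a shorter amino chain would give on the aromatic carbon.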